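Notes on the amine-nitrogen substituent and cell tolerance

The source may hold more compounds than are shown below. What is called first, only, known or untested is meant among the compounds shown, and "the series" means these compounds.

Compound 1 `Cc1cn([C@@H]2O[C@H](CO[Si](C)(C)C(C)(C)C)[C@@]3(OS(=O)(=O)C=C3NCCC(N)=O)[C@H]2O[Si](C)(C)C(C)(C)C)c(=O)n(C)c1=O` carries a 2-carbamoylethyl group on the amine nitrogen of the shared core. In a functional assay on HEL cells (Homo sapiens) (a higher number here means that more compound is tolerated, a lower number that less compound is tolerated), compound 1 gives 14800 nM. Among the two numbers shown, compound 1 holds the highest, with its nearest neighbour compound 2 `CCOC(=O)CNC(=O)NC1=CS(=O)(=O)O[C@@]12[C@@H](CO[Si](C)(C)C(C)(C)C)O[C@@H](n1cc(C)c(=O)n(C)c1=O)[C@@H]2O[Si](C)(C)C(C)(C)C`, which in this assay gives 13000 nM; the step of a 1.1-fold lower number from compound 1 to compound 2 (0.06 log units; within the scatter) is small. The third member, compound 3 `Cc1cn([C@@H]2O[C@H](CO[Si](C)(C)C(C)(C)C)[C@@]3(OS(=O)(=O)C=C3NC(=O)NC(=O)c3ccccc3)[C@H]2O[Si](C)(C)C(C)(C)C)c(=O)n(C)c1=O`, returns only a limit in this assay, >= 200000 nM, and not a number. The steps of an at least 13-fold higher number from compound 1 to compound 3 (1.13 log units; beyond the scatter) and an at least 15-fold higher number from compound 2 to compound 3 (1.18 log units; beyond the scatter) are both large, and both end at the limit of >= 200000 nM in this assay, at which 1 of the 3 values shown sits.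

Compound 4 `Cc1cn([C@@H]2O[C@H](CO[Si](C)(C)C(C)(C)C)[C@@]3(OS(=O)(=O)C=C3NCC(=O)O)[C@H]2O[Si](C)(C)C(C)(C)C)c(=O)n(C)c1=O` is not yet measured. It differs from compound 1 by carboxy in place of carbamoylmethyl on a saturated chain carbon bound to an amine nitrogen. Among the measured compounds shown here, of the measured steps, only the one from compound 1 to compound 2 alters the amine substituent while keeping it a short chain, and that step stayed within the scatter; the large steps to compound 3 involve benzoylcarbamoyl, a group of a different kind from carboxymethyl, and so carry little weight here. The change in compound 4 is a small one, so in this assay no step beyond the scatter is expected, in either direction. The expected step is a 1.2-fold higher number from compound 1 to compound 4 (0.09 log units; within the scatter). Compound 4 is therefore estimated at 18000 nM, within a range from 7000 nM to 50000 nM.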

Compound 4, half-maximal cytotoxic concentration: 136000 nM
Beside the measured number, compound 4's estimate is 7.6-fold (0.88 log units) below it, outside the stated range (above it).
By their numbers in this assay, from the lowest: compounds 2 and 1 (each within the scatter of the next); then compound 4. At a limit, above all of these: compound 3.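

At the amine nitrogen, the substituent matters in this assay even among short chains without a ring: carboxymethyl in place of 2-carbamoylethyl gives a 9.2-fold higher number from compound 1 to compound 4 (0.96 log units; beyond the scatter), and carboxymethyl in place of ((ethoxycarbonyl)methyl)carbamoyl gives a 10-fold higher number from compound 2 to compound 4 (1.02 log units; beyond the scatter). The earlier step, a 1.1-fold lower number from compound 1 to compound 2 (0.06 log units; within the scatter), showed no such separation, and a large move upward had appeared only with benzoylcarbamoyl, so that move no longer belongs to that group alone. The step of an at least 1.4-fold lower number from compound 3 to compound 4 (0.16 log units; that floor lies within the scatter) is a floor only, its starting point being a limit and not a number: the limit of >= 200000 nM in this assay, at which 1 of the 4 values shown sits.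

The shown compounds cannot separate the carboxy group from the shorter chain, as the substituent of compound 4 differs from that of compound 1 in both end group and length. As far as these compounds go, how 2-carboxyethyl, which would keep the chain of compound 1 with the carboxy end, or carbamoylmethyl, which would keep the chain of compound 4 with the amide end, would stand on the amine nitrogen in this assay remains open.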